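The source may report more compounds than this note shows. Statements on the series, on what has been measured and on what is new or still open speak of the compounds shown alone.

Compounds measured in an assay on isolated protein for inhibition of complement C1r subcomponent (Homo sapiens); a higher number here means a weaker inhibitor, a lower number a stronger inhibitor:
compound 1, `O=c1oc(Nc2ccccc2I)nc2cccc(Cl)c12`, 14500 nM
compound 2, `O=c1oc(Nc2ccccc2I)nc2ccc(Cl)cc12`, 4000 nM
compound 3, `Cc1cccc2nc(Nc3ccccc3I)oc(=O)c12`, a limit of the assay, > 62500 nM

Compound 1 and compound 2 are built from the same atoms joined differently; the difference between the two cores is not broken down here. Of the two numbers, compound 2 gives the lower one in this assay, and compound 1 lies beyond the scatter from it. Compound 3 carries the change methyl in place of chloro on an aromatic carbon relative to compound 1. The step of an at least 4.3-fold higher number from compound 1 to compound 3 (0.63 log units; beyond the scatter) is known only as a lower bound because of the limit of > 62500 nM in this assay, at which 1 of the 3 values shown sits.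

Compound 4, `Cc1ccc2nc(Nc3ccccc3I)oc(=O)c2c1`, has not yet been measured in this assay. It carries the change methyl in place of chloro on an aromatic carbon relative to compound 2. This is the same kind of change as that from compound 1 to compound 3, not the same change: in compound 3 the place is ortho to a fused ring and meta to a fused ring, while in compound 4 it is meta to a fused ring and para to a fused ring.

A weakening is expected in this assay. From compound 2 to compound 4 the step is expected to be a 5.0-fold higher number from compound 2 to compound 4 (0.70 log units; beyond the scatter). That expectation rests on the step of an at least 4.3-fold higher number from compound 1 to compound 3 (0.63 log units; beyond the scatter) seen for the same kind of change. Compound 4 is therefore estimated at about 20000 nM, with a range from 6000 nM to 70000 nM, and it may come back as a limit rather than a number.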

Compound 4, half-maximal inhibitory concentration: > 62500 nM
Compound 4 gave a limit, no number; the forecaster's own chance of this, stated with the estimate: 25%; middle value at least 3.1-fold (0.49 log units) away from the limit.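

In this assay, methyl in place of chloro on an aromatic carbon gives a weaker inhibitor on both cores, and on the core of compound 2 the step is an at least 15-fold higher number from compound 2 to compound 4 (1.19 log units; beyond the scatter). Compound 4 gives > 62500 nM, which is a limit of the assay and not a number: the limit of > 62500 nM in this assay, at which 2 of the 4 values shown sit. The direction of the change therefore carries from the core of compound 1 to the core of compound 2, but this pair of cores does not show whether the size of the change carries with it, and the step on one core cannot be used to give a firm size on the other: the same change on two cores in this assay, an at least 4.3-fold higher number (0.63 log units; beyond the scatter) from compound 1 to compound 3 and an at least 15-fold higher number (1.19 log units; beyond the scatter) from compound 2 to compound 4; the limit leaves it open whether they differ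

The compounds shown leave open how weak compound 3 and compound 4 really are, and so whether chloro counts for more on one core than on the other. They also leave open whether another group at these places, such as fluoro, bromo, methoxy or an amine, would keep inhibition at the level seen with chloro or take it further.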